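Moving the branch on the chain of compound 3

The compounds below may be only part of what the source reports. "The series", "measured", "known", "first", "only" and "open" are said of these compounds alone.

Measured so far in an in vitro ADME assay on microsomes from liver (Homo sapiens) for metabolic stability, tested at 5 uM; a higher number here means that the compound lasts longer, a lower number that the compound disappears faster:
- compound 1 (`CC(C)CCn1nc(C2CCCCC2)c(O)c(C2=NS(=O)(=O)c3cc(NS(C)(=O)=O)ccc3N2)c1=O`): 0.117 h
- compound 2 (`CC(C)(C)CCn1nc(-c2cccs2)c(O)c(C2=NS(=O)(=O)c3cc(NS(C)(=O)=O)ccc3N2)c1=O`), a limit: > 1 h
- compound 3 (`CCC(C)(C)Cn1nc(-c2cccs2)c(O)c(C2=NS(=O)(=O)c3cc(NS(C)(=O)=O)ccc3N2)c1=O`), a limit: > 1 h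

In this assay compound 3 gives only a limit, > 1 h, and so it stands at the limit of > 1 h in this assay, at which 2 of the 3 values shown sit, with no number of its own. Compound 4 (`CCC(C)CCn1nc(-c2cccs2)c(O)c(C2=NS(=O)(=O)c3cc(NS(C)(=O)=O)ccc3N2)c1=O`) differs from compound 3 by 2-methylbutyl in place of 1,1-dimethylpropyl on a saturated chain carbon bound to an aromatic nitrogen. Within the data shown here, the one measured step at this place is a step that the two limits leave unreadable from compound 2 to compound 3, so it offers no size to carry over. Compound 1 alone gives a number, 0.117 h, but it differs from compound 2 in more than the chain and is only a loose guide. A modest fall in this assay is therefore expected, with its size poorly fixed. The estimated move is an at least 1.4-fold lower number from compound 3 to compound 4 (0.15 log units; that floor lies within the scatter) on this reading. For compound 4 the estimate is 0.7 h, with an expected range of 0.25 h to 2 h as the upper end.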

Compound 4, half-life: > 1 h
Compound 4 gave a limit, no number; the forecaster's own chance of this, stated with the estimate: 40%; at least 1.4-fold (0.15 log units) between middle value and limit.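

In this assay compound 4 gives only a limit, > 1 h, so its steps from compound 2 and compound 3 cannot be read. The compounds shown leave open whether moving the branch on the chain changes the half-life at all, as compound 2, compound 3 and compound 4 share one reading: the limit of > 1 h in this assay, at which 3 of the 4 values shown sit.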